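Lactone series: hydroxy-to-methoxy change on cytotoxicity

The compounds below may be only part of what the source reports. "The series", "measured", "known", "first", "only" and "open" are said of these compounds alone.

Measured compounds:
compound 1, `O=C1OC[C@H](Cc2ccc(O)cc2)[C@H]1Cc1ccc(Cl)c(Cl)c1`, 37000 nM
compound 2, `COc1ccc(C[C@H]2COC(=O)[C@@H]2Cc2ccc(Cl)c(Cl)c2)cc1`, 37000 nM
compound 3, `COc1ccc(C[C@H]2COC(=O)[C@@H]2Cc2ccc(Cl)c(Cl)c2)cc1O`, 32000 nM

In a functional assay on HL-60 cells (Homo sapiens) for cytotoxicity, read by WST assay, with a stated time of 48 h (a lower number here means that less compound is needed, a higher number that more compound is needed for the effect), compound 1 gives 37000 nM and compound 2 gives 37000 nM. The change between them is methyl in place of hydrogen on an oxygen on an aromatic ring; it gave no change at the digits printed from compound 1 to compound 2 (within the scatter). Compound 3 gives 32000 nM, and a 1.2-fold lower number from compound 2 to compound 3 (0.06 log units; within the scatter). The difference between the cores of compound 1 and compound 3 is not broken down here.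

Compound 4, `COc1ccc(C[C@H]2COC(=O)[C@@H]2Cc2ccc(Cl)c(Cl)c2)cc1OC`, is still to be measured. It differs from compound 3 by methyl in place of hydrogen on an oxygen on an aromatic ring, the same change as that from compound 1 to compound 2, at a place described in the same words. Because that earlier step gave no change at the digits printed from compound 1 to compound 2 (within the scatter), compound 4 is expected to show no change at the digits printed from compound 3 to compound 4 (within the scatter). The estimate for compound 4 is 32000 nM, expected to lie between 14000 nM and 75000 nM.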

Compound 4, half-maximal effective concentration: 24000 nM
For compound 4 the middle estimate is 1.3-fold (0.12 log units) above the measured one; low and high end bracket the measured number.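

In this assay, hydroxy to methoxy gives a 1.3-fold lower number from compound 3 to compound 4 (0.12 log units; within the scatter), and the added methoxy group gives a 1.5-fold lower number from compound 2 to compound 4 (0.19 log units; within the scatter). The methyl change reads alike on the two cores: the same change on two cores in this assay, no change at the digits printed (within the scatter) from compound 1 to compound 2 and a 1.3-fold lower number (0.12 log units; within the scatter) from compound 3 to compound 4, 1.3-fold (0.12 log units) apart, within the scatter of two such steps

So the change carries from the core of compound 1 to the core of compound 3 without a difference that can be told from scatter. With both steps this small, that agreement rests on two pairs and does not show that the change would carry equally to other cores in the series, or to a step large enough to read.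

The compounds shown leave open whether an amine, a carboxylic acid or a longer chain in place of methoxy would give a step beyond the scatter. They also leave open whether any other core would respond differently to such a group.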